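The compounds below may be only part of what the source reports. "The series", "measured", "known", "first", "only" and "open" are said of these compounds alone.

Of the compounds shown here, two that share most of one core have been measured in a functional assay on HCT-116 cells (Homo sapiens) for antiproliferative activity; a lower number here means a stronger inhibitor, a higher number a weaker inhibitor. There, compound 1 `CC[C@H](C)[C@H]1C(=O)N[C@H](Cc2ccc(O)c(Br)c2)C(=O)N[C@@H](C(C)(C)O)C(=O)O[C@H](c2ccccc2)[C@H](C)/C=C/C=C(\C)[C@H](OC)C/C=C(\C)C(=O)N1C` gives 3.88 nM, and compound 2 `CC[C@H](C)[C@H]1C(=O)N[C@H](Cc2cc(Cl)c(O)c(Cl)c2)C(=O)N[C@@H](C(C)C)C(=O)O[C@H](c2ccccc2)[C@H](C)/C=C/C=C(\C)[C@H](OC)C/C=C(\C)C(=O)N1C` gives 21.6 nM. Compound 2 therefore holds the higher, weaker number of the two, and the gap lies beyond the usual scatter of repeated measurements. These two compounds differ in more than one place, so the gap cannot be pinned on any single group.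

Compound 3 `CC[C@H](C)[C@H]1C(=O)N[C@H](Cc2ccc(O)c(Br)c2)C(=O)N[C@@H](C(C)C)C(=O)O[C@H](c2ccccc2)[C@H](C)/C=C/C=C(\C)[C@H](OC)C/C=C(\C)C(=O)N1C` departs from compound 2 in one place only: 3-bromo-4-hydroxyphenyl in place of 3,5-dichloro-4-hydroxyphenyl on a saturated chain carbon bound to a saturated ring carbon. In words, 3-bromo-4-hydroxyphenyl stands in place of 3,5-dichloro-4-hydroxyphenyl on a saturated chain carbon bound to a saturated ring carbon. The incoming group is also carried by compound 1, at 3.88 nM, which gives a weak hint towards a lower number. Going by the values given here, no measured step isolates this change, so the expectation stays loose: a modest gain in this assay, not far beyond the scatter. The expected move is a 2.2-fold lower number from compound 2 to compound 3 (0.33 log units; beyond the scatter). For compound 3 the estimated value is 10 nM, with an expected range from 3.5 nM to 30 nM.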

Compound 3, half-maximal inhibitory concentration: 13.2 nM
The estimate for compound 3 lay 1.3-fold (0.12 log units) below the measured number; measured number inside the range.
By their numbers in this assay, from the lowest: compound 1; then compounds 3 and 2 (each within the scatter of the next).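

In this assay, putting 3-bromo-4-hydroxyphenyl in place of 3,5-dichloro-4-hydroxyphenyl on a saturated chain carbon bound to a saturated ring carbon gives a 1.6-fold lower number from compound 2 to compound 3 (0.21 log units; within the scatter) and so, in this pair, the two rings cannot be told apart. Going by these compounds alone, compound 3 also isolates a second change for the first time: hydrogen in place of hydroxy on a saturated chain carbon bound to two saturated chain carbons and a saturated ring carbon gives a 3.4-fold higher number from compound 1 to compound 3 (0.53 log units; beyond the scatter) and is the only one of the two single changes that lies beyond the scatter. Nothing measured here explains either step.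

From the compounds shown here alone, it remains open whether the ring exchange would also make so little difference in compounds carrying that hydroxy group, since the 3,5-dichloro-4-hydroxyphenyl ring is seen here only with hydrogen at that place. Going by these compounds, how a methoxy group or an amine at the hydroxy place would compare with hydroxy and hydrogen also stays unknown.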